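A change of the aryl group on a sulfonamide nitrogen

A few compounds are considered here, and "the series" means these few. Any claim that something is new, unique, unknown or untested is made for them only; others in the source may bear on it.

Measured compounds:
Compound 1, `CCCCCc1ccc(NS(=O)(=O)c2ccc(N3CCNC3=O)cc2)cc1`: in a functional assay on MCF7 cells (Homo sapiens) for antiproliferative activity, read by sulforhodamine B assay, with a stated time of 48 h (on this read-out higher numbers stand for weaker inhibition and lower numbers for stronger inhibition), compound 1 gives > 1000 nM, a limit of the assay rather than a number.
Compound 2, `Cc1ccccc1NS(=O)(=O)c1ccc(N2CCNC2=O)cc1`: in this assay compound 2 gives 280 nM.
Compound 3, `O=C1NCCN1c1ccc(S(=O)(=O)Nc2cccc(Cl)c2)cc1`: in this assay compound 3 gives 79 nM.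

All three share a core in which a sulfonamide links two aromatic rings, and they differ only in the group on the sulfonamide nitrogen. Compound 3 stands lowest of the two numbers in this assay; the nearest is compound 2, and the step of a 3.5-fold lower number from compound 2 to compound 3 (0.55 log units; beyond the scatter) lies beyond the usual scatter of repeated measurements. Compound 1 sits at a limit of the assay (the limit of > 1000 nM in this assay, at which 1 of the 3 values shown sits), so it cannot be ranked against the others.

Compound 4, `O=C1NCCN1c1ccc(S(=O)(=O)Nc2ccc(F)cc2)cc1`, is not yet measured. It differs from compound 3 as follows: 4-fluorophenyl in place of 3-chlorophenyl on a sulfonamide nitrogen. For the measured compounds named here, only one measured step touches this nitrogen substituent, and it exchanged 2-methylphenyl for 3-chlorophenyl; none compares halogens or their positions with each other. The step of a 3.5-fold lower number from compound 2 to compound 3 (0.55 log units; beyond the scatter) shows that the aryl group here matters at a modest scale. Without a closer precedent, the expectation for a 2.5-fold higher number from compound 3 to compound 4 (0.40 log units; beyond the scatter) is a modest rise in the number, with wide uncertainty. Compound 4 is therefore estimated at 200 nM, in a range from 70 nM to 600 nM.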

Compound 4, half-maximal inhibitory concentration: 690 nM
Beside the measured number, compound 4's estimate is 3.5-fold (0.54 log units) below it; measured number outside the range, above it.
By their numbers in this assay, from the lowest: compound 3; then compound 2; then compound 4. At a limit, above all of these: compound 1.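

Even between two aryl groups that match in everything counted here, including heavy atoms, and differ in the identity and place of the halogen, the number moves by a modest step: in this assay there is an 8.7-fold higher number from compound 3 to compound 4 (0.94 log units; beyond the scatter). For the compounds shown here, the 2-methylphenyl group also gives a different number from the 4-fluorophenyl group, with a 2.5-fold higher number from compound 2 to compound 4 (0.39 log units; beyond the scatter), so the three measured aryl groups spread out in clearly separated steps and this sulfonamide nitrogen substituent proves more sensitive than the single earlier step could show. The remaining step is an at least 1.4-fold lower number from compound 1 to compound 4 (0.16 log units; that floor lies within the scatter). That comparison gives a floor and no order, because the value of compound 1 is a limit of the assay: the limit of > 1000 nM in this assay, at which 1 of the 4 values shown sits.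

Since chlorine gives way to fluorine and the halogen's place changes in the same step, the compounds shown cannot tell which of the two accounts for the rise. They also leave open how the number would respond to an aryl group carrying a methoxy group, an amine or a carboxylic acid, or to a shorter chain than the pentyl of compound 1.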